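This account rests on a few compounds, and the source may have more. Where it says the series, first, only, none or still open, it means among the compounds named here.

Measured so far:
compound 1, `COc1ccc2c(c1)c(CC(=O)O)c(C)n2Cc1ccc(-c2cn(CCCCCCC(=O)NO)nn2)cc1`, 9900 nM;
compound 2, `COC(=O)Cc1c(C)n(Cc2ccc(-c3cn(CCCCCCCC(=O)NO)nn3)cc2)c2ccc(OC)cc12`, 1280 nM;
compound 3, `Cc1ccc(-c2cc(C(=O)NCCCCCC(=O)NO)nn2-c2ccc(S(N)(=O)=O)cc2)cc1`, "not determined" (no result reported).

In a functional assay on HCT-116 cells (Homo sapiens) for inhibition, read by MTT assay, with a stated time of 72 h (on this read-out higher numbers stand for weaker inhibition and lower numbers for stronger inhibition), compound 2 gives 1280 nM, the lower of the two numbers; compound 1 gives 9900 nM, a gap described as beyond the scatter, while compound 3 stands without a number. Compound 4, `COC(=O)Cc1c(C)n(Cc2ccc(-c3cn(CCCCCC(=O)NO)nn3)cc2)c2ccc(OC)cc12`, differs from compound 2 by hydroxycarbamoyl in place of 2-(hydroxycarbamoyl)ethyl on a saturated chain carbon, five bonds along the chain from an aromatic nitrogen. For the measured compounds named here, no measured pair shows this change on its own, so the direction rests on expectation alone: the shorter chain is estimated to weaken inhibition by a moderate step, a 2.7-fold higher number from compound 2 to compound 4 (0.44 log units; beyond the scatter), beyond the scatter but not far. Compound 4 is therefore expected to give about 3500 nM, within a range from 1200 nM to 10000 nM.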

Compound 4, half-maximal inhibitory concentration: 9310 nM
Estimate against measurement, compound 4: 2.7-fold (0.42 log units) below, within the range that was stated.
By their numbers in this assay, from the lowest: compound 2; then compounds 4 and 1 (each within the scatter of the next).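

In this assay, for the compounds shown here, hydroxycarbamoyl in place of 2-(hydroxycarbamoyl)ethyl on a saturated chain carbon, five bonds along the chain from an aromatic nitrogen, gives a 7.3-fold higher number from compound 2 to compound 4 (0.86 log units; beyond the scatter) and so provides the first reading of a single change. At this position, the shorter chain clearly weakens inhibition. Nothing available explains why the step has this size.
The compounds shown leave open whether a chain longer than that of compound 2 would lower the number further. They also leave open how a carboxylic acid in place of the methyl ester would read at a fixed chain length.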